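Swapping Benzyl for Carbamate on a Bridged Ring Amine

The source may report more compounds than this note shows. Statements on the series, on what has been measured and on what is new or still open speak of the compounds shown alone.

Measured compounds:
compound 1, `COc1cc2nc(Nc3ccc(S(C)(=O)=O)cc3)nc(N3CCC4CCC(C3)N4Cc3ccccc3)c2cc1OC`: 32.8%
compound 2, `COc1cc2nc(OC3CCN(C(=O)OC(C)(C)C)CC3)nc(Nc3ccc(S(C)(=O)=O)cc3F)c2cc1OC`: 19.6%

Among the measured compounds shown here, in a functional assay on HEK293 cells for agonist activity at Glucose-dependent insulinotropic receptor (Homo sapiens), read by cAMP accumulation, with a stated time of 60 min (a lower number here means a smaller maximal response, a higher number a larger maximal response), compound 1 gives 32.8%, the higher of the two numbers known. Compound 2 gives 19.6% in this assay, a gap that lies beyond the usual scatter. For the measured compounds named here, the two compounds differ in several places at once, so their values show only that the two read-outs sit apart; no single-change step between measured compounds is available.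

Compound 3, `COc1cc2nc(Nc3ccc(S(C)(=O)=O)cc3)nc(N3CCC4CCC(C3)N4C(=O)OC(C)(C)C)c2cc1OC`, has not yet been measured in this assay. It differs from compound 1 by tert-butoxycarbonyl in place of benzyl on an amine nitrogen in a ring.

Compound 2 also bears a tert-butoxycarbonyl, but on a different ring and with other changes, so it does not calibrate this step. With nothing to lean on, a modest change downward is expected, of a size near the edge of the scatter. The step is estimated at a number 7.8 percentage points lower from compound 1 to compound 3 (within the scatter). Compound 3 is therefore expected to reach about 25% in this assay, within a range from 10% to 42%.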

Compound 3, largest response reached (Emax), in percent of the reference or control that the assay uses: 37.5%
Compound 3: the middle estimate sits 12.5 percentage points below what was measured; low and high end bracket the measured number.
By their numbers in this assay, from the lowest: compound 2; then compounds 1 and 3 (each within the scatter of the next).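

In this assay, tert-butoxycarbonyl in place of benzyl on this amine nitrogen in a ring gives a step of a number 4.7 percentage points higher from compound 1 to compound 3 (within the scatter), the first single-change comparison among the compounds shown. The maximal response therefore does not separate these two groups at this place, although the group that leaves carries one six-membered aromatic ring of carbon only and 0 hydrogen-bond acceptors, while the group that enters has no ring and 2 hydrogen-bond acceptors. No measurement is available that would explain this result.

The compounds shown leave open whether an unsubstituted amine, an acetyl group or a longer alkyl chain on the same nitrogen would give a response in the same range, as this single step covers only two groups. They also leave open whether the same exchange would give a similar result on a different ring amine, a question compound 2 cannot answer, as it differs from compound 1 and compound 3 in several places at once.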